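From methoxy to nitro at one aromatic carbon

The source may report more compounds than this note shows. Statements on the series, on what has been measured and on what is new or still open speak of the compounds shown alone.

Of the compounds shown here, two with a shared core have been measured so far. In a functional assay on U-937 cells (Homo sapiens) for antiproliferative activity, read by CCK-8 assay, with a stated time of 72 h (on this read-out higher numbers stand for weaker inhibition and lower numbers for stronger inhibition), compound 1 `Cc1cc(Nc2cc(N3CCN(C)CC3)nc(Nc3ccc([N+](=O)[O-])cc3)n2)n[nH]1`, which carries a 4-nitrophenyl group, gives 43.3 nM. Compound 2 `COc1cccc(Nc2nc(Nc3cc(C)[nH]n3)cc(N3CCN(C)CC3)n2)c1`, with a 3-methoxyphenyl group instead, gives 126 nM, the higher of the two numbers and thus the weaker inhibition of the pair.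

Compound 3 `Cc1cc(Nc2cc(N3CCN(C)CC3)nc(Nc3cccc([N+](=O)[O-])c3)n2)n[nH]1` keeps the core of compound 2 but has nitro in place of methoxy on an aromatic carbon, meta to a large group: nitro in place of methoxy on an aromatic carbon. Going by the values given here, only one measured step bears on this change: a 2.9-fold higher number from compound 1 to compound 2 (0.46 log units; beyond the scatter), a modest step beyond the scatter. Among the compounds with values here, that step also moves the substituent to another position, so it is only a partial guide, and no measured compound carries the 3-nitrophenyl group. Even so, the one nitrophenyl compound measured has the lower number, so a modest downward step is expected in this assay. The expected change is a 1.8-fold lower number from compound 2 to compound 3 (0.26 log units; within the scatter). Compound 3 is estimated at 70 nM, with an expected range from 25 nM to 190 nM.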

Compound 3, half-maximal inhibitory concentration: 25.2 nM
Compound 3: middle estimate off by 2.8-fold (0.44 log units), on the high side, within the range that was stated.
By their numbers in this assay, from the lowest: compounds 3 and 1 (each within the scatter of the next); then compound 2.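

In this assay the change from methoxy to nitro can now be read on its own at one aromatic carbon, meta to a large group, and it gives a 5.0-fold lower number from compound 2 to compound 3 (0.70 log units; beyond the scatter) in a step that the earlier pair could not isolate, since that pair changed both group and position. Moving the nitro group gives a 1.7-fold lower number from compound 1 to compound 3 (0.24 log units; within the scatter) and so leaves the 3-nitrophenyl and 4-nitrophenyl compounds indistinguishable in this read-out, which means that the position of the nitro group on the phenyl ring shows no readable effect across this pair. No available evidence explains why nitro and methoxy differ here.

The compounds shown leave open whether the same position-independence holds for methoxy, as a 4-methoxyphenyl partner for compound 2 would be needed to test that. They also leave open whether the lower number belongs to nitro alone or would also be seen with a nitrile, a trifluoromethyl group or an amine on the same aromatic carbon.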